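Indole in place of isoquinoline on the longer amide chain

A few compounds are considered here, and "the series" means these few. Any claim that something is new, unique, unknown or untested is made for them only; others in the source may bear on it.

Compound 1 `CCCCCCCCCCCCCCNC(=O)[C@@H](NC(=O)c1nccc2ccccc12)[C@@H](C)O` gives 28600 nM in a functional assay on HepG2 cells (Homo sapiens) for cytotoxicity, read by MTT assay, with a stated time of 48 h; a higher number here means a weaker inhibitor, a lower number a stronger inhibitor. Compound 2 `CCCCCCCCCCCCCCNC(=O)[C@@H](NC(=O)c1cc2ccccc2[nH]1)[C@@H](C)O` gives 10500 nM in this assay. Compound 3 `CCCCCCCCCCCCCCCCCCNC(=O)[C@@H](NC(=O)c1nccc2ccccc12)[C@@H](C)O` gives 96900 nM in this assay, the highest number of the three measured, its steps to the other two both beyond the scatter. Compound 4 `CCCCCCCCCCCCCCCCCCNC(=O)[C@@H](NC(=O)c1cc2ccccc2[nH]1)[C@@H](C)O` has not yet been measured.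

Two single-point changes are shown among the measured compounds. Compound 2 differs from compound 1 by 1H-indol-2-yl in place of isoquinolin-1-yl on a carbonyl carbon, and the step was a 2.7-fold lower number from compound 1 to compound 2 (0.44 log units; beyond the scatter). Compound 3 differs from compound 1 by butyl in place of hydrogen on a saturated chain carbon, ten or more bonds along the chain from an amide-type nitrogen, and the step was a 3.4-fold higher number from compound 1 to compound 3 (0.53 log units; beyond the scatter).

Compound 4 differs from compound 3 by 1H-indol-2-yl in place of isoquinolin-1-yl on a carbonyl carbon. The place is described in the same words as for the change from compound 1 to compound 2, so this is the same change, made in both pairs among the compounds shown, with only one measured instance.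

For compound 4 in this assay the expected step is a 2.7-fold lower number from compound 3 to compound 4 (0.43 log units; beyond the scatter). This rests on a 2.7-fold lower number from compound 1 to compound 2 (0.44 log units; beyond the scatter) applied to the value of compound 3, 96900 nM, with a single precedent giving wide uncertainty. Compound 4 is expected at 36000 nM, with a range from 15000 nM to 90000 nM.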

Compound 4, half-maximal inhibitory concentration: 89400 nM
For compound 4 the middle estimate is 2.5-fold (0.40 log units) below the measured one; the measured number falls inside the stated range.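

In this assay, 1H-indol-2-yl in place of isoquinolin-1-yl on the carbonyl carbon gives a 1.1-fold lower number from compound 3 to compound 4 (0.03 log units; within the scatter), and this step cannot be told apart from the earlier one on the shorter chain: the same change on two cores in this assay, a 2.7-fold lower number (0.44 log units; beyond the scatter) from compound 1 to compound 2 and a 1.1-fold lower number (0.03 log units; within the scatter) from compound 3 to compound 4, 2.5-fold (0.40 log units) apart, within the scatter of two such steps. Butyl in place of hydrogen on the saturated chain carbon gives an 8.5-fold higher number from compound 2 to compound 4 (0.93 log units; beyond the scatter), a higher number on both aromatic amides, and here too the two steps are not told apart: the same change on two cores in this assay, a 3.4-fold higher number (0.53 log units; beyond the scatter) from compound 1 to compound 3 and an 8.5-fold higher number (0.93 log units; beyond the scatter) from compound 2 to compound 4, 2.5-fold (0.40 log units) apart, within the scatter of two such steps. Both changes are thus consistent with carrying over between cores in these four compounds, but with only two instances of each, this does not show whether the step for the aromatic group truly shrinks on the longer chain or stays the same.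

The compounds shown cover only two chain lengths and two aromatic groups, so it remains open how either change behaves with a shorter chain. Also open, going by these compounds, is what happens when an amine or a carboxylic acid is carried on the chain.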